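This account rests on a few compounds, and the source may have more. Where it says the series, first, only, none or still open, it means among the compounds named here.

compound 1 `C=CC(=O)Nc1ccc(Cn2nc(-c3ccc(Oc4ccccc4)cc3)cc2C(=O)O)cc1` — > 60000 nM
compound 2 `C/C=C/C(=O)Nc1ccc(Cn2nc(-c3ccc(Oc4ccccc4)cc3)cc2C(=O)O)cc1` — > 60000 nM
compound 3 `O=C(CCl)Nc1ccc(Cn2nc(-c3ccc(Oc4ccccc4)cc3)cc2CO)cc1` — 400 nM

Within the data shown here, in a functional assay on Z-138 cells (Homo sapiens) for inhibition, read by luminescence and CellTiter-Glo, with a stated time of 72 h (a lower number here means a stronger inhibitor, a higher number a weaker inhibitor), compound 3 gives the only real number of the three. For compound 1 the reading is a limit, (the limit of > 60000 nM in this assay, at which 2 of the 3 values shown sit). For compound 2 the reading is likewise a limit. Compound 4 `O=C(CCl)Nc1ccc(Cn2nc(-c3ccc(Oc4ccccc4)cc3)cc2C(=O)O)cc1` differs from compound 3 in one place: carboxy in place of hydroxymethyl on an aromatic carbon. Among the measured compounds shown here, no measured step covers this change; the step that the two limits leave unreadable from compound 1 to compound 2 concerns the group on the carbonyl carbon and is unreadable. Compounds 1 and 2, which carry the carboxy group together with a different group on the carbonyl carbon, both sit at the limit. Compound 4 is therefore expected to be a weaker inhibitor than compound 3, a step of a 13-fold higher number from compound 3 to compound 4 (1.10 log units; beyond the scatter), with an estimate of 5000 nM (800 nM to 60000 nM).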

Compound 4, half-maximal inhibitory concentration: 1500 nM
For compound 4 the middle estimate is 3.3-fold (0.52 log units) above the measured one, and the stated range covers the measured number.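

In this assay, the carboxy group on this aromatic carbon is tolerated with only a limited loss: a 3.8-fold higher number from compound 3 to compound 4 (0.57 log units; beyond the scatter). With the carboxy group kept, the group on the carbonyl carbon matters much more, as chloromethyl gives an at least 40-fold lower number from compound 2 to compound 4 (1.60 log units; beyond the scatter) and an at least 40-fold lower number from compound 1 to compound 4 (1.60 log units; beyond the scatter). Compound 1 and compound 2 each stand at a limit, not a number: the limit of > 60000 nM in this assay, at which 2 of the 4 values shown sit.

The compounds shown leave open how a primary amide or a methyl ester would read on this aromatic carbon. They also leave open how vinyl on the carbonyl carbon would read alongside hydroxymethyl.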